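Sulfonyl anilino series: fluoro in place of amino

This account rests on a few compounds, and the source may have more. Where it says the series, first, only, none or still open, it means among the compounds named here.

Compound 3 `Cc1ccc(S(=O)(=O)c2nc3ccccc3nc2Nc2ccc(N)cc2)cc1` gives 11500 nM in a functional assay on HCT-116 cells (Homo sapiens) for cytotoxicity, read by MTT assay, with a stated time of 72 h; on this read-out lower numbers stand for stronger inhibition and higher numbers for weaker inhibition; of the two numbers shown it is the highest, the nearest being compound 1 `O=S(=O)(c1ccccc1)c1nc2ccccc2nc1Nc1ccc(F)cc1` with 5190 nM, a gap beyond the scatter. Compound 2 `COc1ccc(Nc2nc3ccccc3nc2S(=O)(=O)c2ccc(C)cc2)cc1` returns only a limit in this assay, namely > 50000 nM. That limit is the one at which one of the three values shown sits (the limit of > 50000 nM in this assay, at which 1 of the 3 values shown sits). The measured step of an at least 4.3-fold lower number from compound 2 to compound 3 (0.63 log units; beyond the scatter) shows an at least modest gain.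

Compound 4 `Cc1ccc(S(=O)(=O)c2nc3ccccc3nc2Nc2ccc(F)cc2)cc1` has not yet been measured. It differs from compound 3 by fluoro in place of amino on an aromatic carbon. For the measured compounds named here, the single measured step touches the same place but exchanges methoxy for amino, not amino for fluoro, so it bears only indirectly on the present change. More useful is compound 1, which carries fluoro at that place and differs from compound 4 only by a methyl group; compound 1 at 5190 nM sits beyond the scatter below compound 3. Compound 4 is therefore expected to fall with compound 1 rather than with compound 3, and the step of a 2.1-fold lower number from compound 3 to compound 4 (0.32 log units; beyond the scatter) is expected to be a lowering of modest size. Compound 4 is estimated at 5500 nM, with a range from 2500 nM to 12000 nM.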

Compound 4, half-maximal inhibitory concentration: 10500 nM
Compound 4: middle estimate off by 1.9-fold (0.28 log units), on the low side; the range from low to high includes it.
By their numbers in this assay, from the lowest: compound 1; then compounds 4 and 3 (each within the scatter of the next). At a limit, above all of these: compound 2.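

In this assay, fluoro in place of amino on the aromatic carbon para to a large group gives a 1.1-fold lower number from compound 3 to compound 4 (0.04 log units; within the scatter), so these two groups cannot be told apart at this place. Compound 2 stands at a limit, > 50000 nM, and its step is therefore a bound only; with an at least 4.7-fold lower number from compound 2 to compound 4 (0.67 log units; beyond the scatter), methoxy remains the group that stands apart from both fluoro and amino at this place. With fluoro held constant, the change elsewhere in the molecule does lie beyond the scatter, as a 2.0-fold higher number from compound 1 to compound 4 (0.31 log units; beyond the scatter) shows for methyl in place of hydrogen on an aromatic carbon, so in this pair the methyl group carries a modest step while the amino-to-fluoro exchange carries none.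

No measured property in the material at hand bears on why these steps take the sizes they do. Going by these compounds, it remains open whether a hydroxyl group, a dimethylamino group or a carboxylic acid at this place would fall with fluoro and amino or with methoxy, and whether the methyl step would hold with amino or methoxy in place of fluoro.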